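Swapping bromo for iodo on compound 3

The compounds below may be only part of what the source reports. "The series", "measured", "known", "first", "only" and "open" are said of these compounds alone.

In an ADME assay on L1210/0 cells (Mus musculus) for cytotoxicity, with a stated time of 48 h (on this read-out higher numbers stand for weaker inhibition and lower numbers for stronger inhibition), compound 1 `CC1(C)[C@@H](Cn2cnc3c(Cl)nc(N)nc32)CC[C@@]1(C)CO` gives 50000 nM and compound 2 `Cc1ccc(S(=O)(=O)/C=C/[C@H]2O[C@@H](n3cnc4c(N)ncnc43)[C@@H](O)[C@H]2O)cc1` gives 54000 nM on the same scale. Compound 3 `O=C1O/C(=C\Cn2cc(Br)c(=O)[nH]c2=O)C(OCc2ccccc2)=C1OCc1ccccc1` stands lowest of the three at 7500 nM and its gaps to both others lie beyond the scatter. Compound 4 `O=C1O/C(=C\Cn2cc(I)c(=O)[nH]c2=O)C(OCc2ccccc2)=C1OCc1ccccc1` is still unmeasured and differs from it by iodo in place of bromo on an aromatic carbon. Within the data shown here, no measured pair shows what such a swap does, so the expectation rests only on compound 3 at 7500 nM and on the change itself. In this assay no step beyond the scatter is expected, only a slight drift to lower numbers (a 1.3-fold lower number from compound 3 to compound 4 (0.10 log units; within the scatter)). The estimated value for compound 4 is 6000 nM (expected range 2500 nM to 15000 nM).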

Compound 4, half-maximal inhibitory concentration: 7500 nM
Estimate against measurement, compound 4: 1.3-fold (0.10 log units) below; measured number inside the range.
By their numbers in this assay, from the lowest: compounds 3 and 4 (each within the scatter of the next); then compounds 1 and 2 (each within the scatter of the next).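

In this assay, iodo in place of bromo on an aromatic carbon of the six-membered aromatic ring with 2 nitrogen gives no change at the digits printed from compound 3 to compound 4 (within the scatter). Among these compounds, this is the first swap at this position that can be read, and the read-out does not register the exchange of one of these halogens for the other. Nothing at hand explains why the two compounds match.

On these data alone, whether this position accepts only these two halogens stays open. An amine, a methyl group or a carboxylic acid on the same carbon could leave the number alone or shift it in either direction.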